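A Trimethoxyphenyl Swap in a Level Cytotoxicity Series

The source may report more compounds than this note shows. Statements on the series, on what has been measured and on what is new or still open speak of the compounds shown alone.

In a functional assay on HepG2 cells (Homo sapiens) for cytotoxicity, read by MTT assay, with a stated time of 72 h (on this read-out higher numbers stand for weaker inhibition and lower numbers for stronger inhibition), compound 1 `O=C(N/N=C/c1cccc(Br)c1)Nc1cc2c(Nc3ccc(F)c(Cl)c3)ncnc2cc1O[C@H]1CCOC1` gives 32300 nM, compound 2 `N#Cc1ccc(/C=N/NC(=O)Nc2cc3c(Nc4ccc(F)c(Cl)c4)ncnc3cc2O[C@H]2CCOC2)cc1` gives 26400 nM and compound 3 `COc1cc2ncnc(Nc3ccc(F)c(Cl)c3)c2cc1NC(=O)N/N=C/c1ccc(C#N)cc1` gives 34100 nM, so compound 3 stands level with the other two, within the scatter. Compound 4 `COc1cc2ncnc(Nc3ccc(F)c(Cl)c3)c2cc1NC(=O)N/N=C/c1cc(OC)c(OC)c(OC)c1` differs from compound 3 at one place: 3,4,5-trimethoxyphenyl in place of 4-cyanophenyl on a carbon with a double bond to nitrogen. For the measured compounds named here, the closest precedent is a 1.2-fold lower number from compound 1 to compound 2 (0.09 log units; within the scatter), a change on that same carbon with a double bond to nitrogen. The change on the oxygen, a 1.3-fold higher number from compound 2 to compound 3 (0.11 log units; within the scatter), lies elsewhere in the molecule. Going by the values given here, both steps remain within the scatter, although no measured compound carries 3,4,5-trimethoxyphenyl. The expected step is therefore a 1.1-fold lower number from compound 3 to compound 4 (0.06 log units; within the scatter), with no change expected beyond the scatter. Compound 4 is estimated at 30000 nM, with an expected range from 14000 nM to 60000 nM.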

Compound 4, half-maximal inhibitory concentration: 30100 nM
Beside the measured number, compound 4's estimate is 1.0-fold (0.00 log units) below it, within the range that was stated.
By their numbers in this assay, from the lowest: compounds 2, 4, 1 and 3 (each within the scatter of the next).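

In this assay, 3,4,5-trimethoxyphenyl in place of 4-cyanophenyl on the carbon with a double bond to nitrogen gives a 1.1-fold lower number from compound 3 to compound 4 (0.05 log units; within the scatter), so a group of 12 heavy atoms with three oxygens, entering for one of 8, leaves the number level. This position now stays within the scatter across a second, larger exchange of groups. No measurement at hand accounts for this. Going by these compounds, whether an amine or a carboxylic acid on this phenyl ring would move the number beyond the scatter remains open, as does the effect of a longer chain in its place.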